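Compound 1 to compound 3: trifluoromethyl for bromo

The source may report more compounds than this note shows. Statements on the series, on what has been measured and on what is new or still open speak of the compounds shown alone.

Among the measured compounds shown here, in a functional assay on MKN-45 cells (Homo sapiens) for cytotoxicity, read by MTT assay, with a stated time of 72 h (on this read-out higher numbers stand for weaker inhibition and lower numbers for stronger inhibition), compound 1 `O=C(N/N=C/c1ccc(Br)cc1)N1CCc2ncnc(Nc3cccc(Br)c3)c2C1` gives 23600 nM, the only actual number so far. Compound 2 `O=C(N/N=C/c1cccs1)N1CCc2ncnc(Nc3cccc(Br)c3)c2C1` gives > 200000 nM, which is a limit of the assay and not a number.

Compound 3 `O=C(N/N=C/c1ccc(Br)cc1)N1CCc2ncnc(Nc3cccc(C(F)(F)F)c3)c2C1` is the next case, and it differs from compound 1 by a single change trifluoromethyl in place of bromo on an aromatic carbon, meta to a large group. For the measured compounds named here, the one measured step is an at least 8.4-fold higher number from compound 1 to compound 2 (0.92 log units; beyond the scatter). It puts thiophen-2-yl in place of 4-bromophenyl on a carbon with a double bond to nitrogen, which is a different place, so it bears only indirectly: it shows that the series can respond to a change, but not how this one will go.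

Going by the values given here, no measured step covers the 3-bromophenyl position, so no direction can be argued and the expectation stays anchored on compound 1 at 23600 nM. The expected 1.1-fold lower number from compound 1 to compound 3 (0.03 log units; within the scatter) is not beyond the scatter in this assay, though the uncertainty is wide. For compound 3 the estimate is 22000 nM, with an expected range of 8000 nM to 70000 nM.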

Compound 3, half-maximal inhibitory concentration: 11400 nM
Compound 3: middle estimate off by 1.9-fold (0.29 log units), on the high side; measured number inside the range.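

Among the compounds shown here, the (3-bromophenyl)amino part now has a measured step of its own, which the earlier compounds did not give: in this assay trifluoromethyl in place of bromo on the aromatic carbon gives a 2.1-fold lower number from compound 1 to compound 3 (0.32 log units; beyond the scatter) and so shows that this position responds to a change of substituent. The step is modest, and the 4-bromophenyl end stays the same in both compounds, so it can be read for this position alone, with a real number at each end. Nothing shown gives a cause for this step.

Still open, on these data alone, is how a nitrile, a methoxy group, an amine or a carboxylic acid would read at this same place on the ring, and whether a plain phenyl without any substituent there would sit with compound 1 or compound 3, so one step gives a single comparison and no trend across substituents. Also open, as far as these compounds go, is whether trifluoromethyl would have any effect with the thiophen-2-yl end of compound 2, whose reading is a limit and not a number.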